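The compounds below may be only part of what the source reports. "The series", "measured", "known", "first", "only" and "open" are said of these compounds alone.

In a functional assay on MCF7 cells (Homo sapiens) for cytotoxicity, read by MTT assay, with a stated time of 48 h (on this read-out higher numbers stand for weaker inhibition and lower numbers for stronger inhibition), compound 1 `Cc1ccc(/C=C2/S/C(=N/c3ccccc3)N(Cc3ccncc3)C2=O)cc1` gives 36900 nM, compound 2 `O=C1/C(=C\c2ccc(O)cc2)S/C(=N/c2ccccc2)N1Cc1ccncc1` gives 18900 nM and compound 3 `CN(C)c1ccc(/C=C2/S/C(=N/c3ccccc3)N(Cc3ccncc3)C2=O)cc1` gives 76300 nM, the highest of the three numbers. The next compound, compound 4 `CC(C)c1ccc(/C=C2/S/C(=N/c3ccccc3)N(Cc3ccncc3)C2=O)cc1`, differs from compound 3 by isopropyl in place of dimethylamino on an aromatic carbon, which is isopropyl in place of dimethylamino on an aromatic carbon. Two measured steps involve the same dimethylamino group. The one from methyl, the group closest to isopropyl among those measured, is a 2.1-fold higher number from compound 1 to compound 3 (0.32 log units; beyond the scatter), and the one from hydroxy is a 4.0-fold higher number from compound 2 to compound 3 (0.61 log units; beyond the scatter). Both are modest. Leaving dimethylamino is therefore expected to give a modest step towards a lower number in this assay, estimated as a 2.1-fold lower number from compound 3 to compound 4 (0.33 log units; beyond the scatter). The expected value for compound 4 is 36000 nM, with an estimated range from 15000 nM to 85000 nM.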

Compound 4, half-maximal inhibitory concentration: 53300 nM
Compound 4: middle estimate off by 1.5-fold (0.17 log units), on the low side; the measured number falls inside the stated range.
By their numbers in this assay, from the lowest: compounds 2, 1, 4 and 3 (each within the scatter of the next, the first and the last beyond it).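

In this assay, isopropyl cannot be told apart at this position from either dimethylamino, with a 1.4-fold lower number from compound 3 to compound 4 (0.16 log units; within the scatter), or methyl, with a 1.4-fold higher number from compound 1 to compound 4 (0.16 log units; within the scatter); exchanging the dimethylamino nitrogen and its hydrogen-bond acceptor for carbon, at an equal heavy-atom count, therefore has no readable effect. Of the groups compared with isopropyl, only hydroxy stands apart, with a 2.8-fold higher number from compound 2 to compound 4 (0.45 log units; beyond the scatter). No evidence bears on the reason for these steps. The compounds shown leave open whether a carboxylic acid or a longer alkyl chain on this aromatic carbon would move the number beyond the scatter from methyl.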